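Replacing the cyclohexyl amide with a sulfonamide

The source may hold more compounds than are shown below. What is called first, only, known or untested is meant among the compounds shown, and "the series" means these compounds.

Compound 1 `CCC(=O)N1CCc2nc(C#Cc3ccccc3)sc2C1`: 38 nM
Compound 2 `O=C(C1CCCCC1)N1CCc2nc(C#Cc3ccccc3)sc2C1`: > 10000 nM

In an assay on HEK293 cells for negative allosteric modulation of metabotropic glutamate receptor 5 (Homo sapiens), read by FLIPR, with a stated time of 1 h (on this read-out lower numbers stand for stronger inhibition and higher numbers for weaker inhibition), compound 1 gives 38 nM. Compound 2 gives > 10000 nM, which is a limit of the assay rather than a number (the limit of > 10000 nM in this assay, at which 1 of the 2 values shown sits). Compound 2 therefore stands at the weak end of the two measured values, reached through an at least 260-fold higher number from compound 1 to compound 2 (2.42 log units; beyond the scatter). Compound 3 `CC(C)S(=O)(=O)N1CCc2nc(C#Cc3ccccc3)sc2C1` differs from compound 2 by isopropylsulfonyl in place of cyclohexylcarbonyl on an amine nitrogen in a ring. Within the data shown here, the only measured step shows a large loss on moving to the larger group, and the entering group is smaller, so a move back toward lower numbers is expected, of the size an at least 20-fold lower number from compound 2 to compound 3 (1.30 log units; beyond the scatter). Compound 3 is estimated at 500 nM, between 60 nM and 4000 nM.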

Compound 3, half-maximal inhibitory concentration: 11 nM
Compound 3: middle estimate off by 45-fold (1.66 log units), on the high side, and the stated range ends above it.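

On the amine nitrogen in a ring, isopropylsulfonyl in place of cyclohexylcarbonyl gives an at least 900-fold lower number from compound 2 to compound 3 (2.95 log units; beyond the scatter) in this assay, so the position does not lose activity with every group larger than propanoyl. The starting value of this step is a limit for compound 2 and not a number: the limit of > 10000 nM in this assay, at which 1 of the 3 values shown sits. Isopropylsulfonyl in place of propanoyl gives a 3.5-fold lower number from compound 1 to compound 3 (0.54 log units; beyond the scatter), so the sulfonyl group does more than recover the level of the amide. The compounds shown leave open whether the sulfonyl or the isopropyl carries this gain: an isobutyryl group or a cyclohexylsulfonyl group on the same nitrogen would separate the two.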